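The source may hold more compounds than are shown below. What is called first, only, known or untested is meant among the compounds shown, and "the series" means these compounds.

Compound 3 `Cc1nn(-c2ncnc3nc[nH]c23)c2c1C(OCc1ccccc1Cl)CC(=O)N2` gives 2 nM in a functional assay on HEK293 cells for agonist activity at G-protein coupled receptor 39 (Homo sapiens), read by scintillation proximity assay and inositol phosphate accumulation, with a stated time of 75 min, in the presence of a further agent that is not named here (on this read-out lower numbers stand for an effect already at smaller amounts and higher numbers for an effect only at larger amounts of compound), and holds the lowest number of the three measured compounds. Compound 1 `Cc1noc(C)c1COC1CC(=O)Nc2c1c(C)nn2-c1ncnc2nc[nH]c12` gives 5 nM and compound 2 `Cc1nn(-c2ncnc3nc[nH]c23)c2c1C(OCc1ccc(C(C)C)cc1)CC(=O)N2` gives 5 nM, and those two sit within the scatter of each other: no change at the digits printed from compound 1 to compound 2 (within the scatter). Against each of them compound 3 stands apart by a modest, real margin: a 2.5-fold lower number from compound 1 to compound 3 (0.40 log units; beyond the scatter) and a 2.5-fold lower number from compound 2 to compound 3 (0.40 log units; beyond the scatter).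

Compound 4 `Cc1cc(C)n(CCOC2CC(=O)Nc3c2c(C)nn3-c2ncnc3nc[nH]c23)n1` carries the change ((3,5-dimethyl-1H-pyrazol-1-yl)methyl in place of 2-chlorophenyl on a saturated chain carbon bound to an oxygen on a saturated carbon). Among the compounds with values here, the side group again becomes a five-membered aromatic ring with two hetero atoms, as in compound 1, but now linked through an extra saturated carbon, and no measured pair speaks to that longer link. Within the data shown here, the steps that bear on the change are the two that lead into compound 3: the move from a 3,5-dimethyl-1,2-oxazol-4-yl or a 4-isopropylphenyl group to 2-chlorophenyl lowered the number modestly, so the reverse move, away from 2-chlorophenyl to a heteroaromatic side group, is expected to raise the number by a similar modest amount, a 3.0-fold higher number from compound 3 to compound 4 (0.48 log units; beyond the scatter), landing near compound 1. Compound 4 is therefore estimated at 6 nM, expected between 2 nM and 20 nM.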

Compound 4, half-maximal effective concentration: 16 nM
Beside the measured number, compound 4's estimate is 2.7-fold (0.43 log units) below it, and the stated range covers the measured number.
By their numbers in this assay, from the lowest: compound 3; then compounds 1 and 2 (each within the scatter of the next); then compound 4.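

Within the data shown here, at this place, on a saturated chain carbon bound to an oxygen on a saturated carbon, compound 4 is the first group to stand clearly apart from all the others, with an 8.0-fold higher number from compound 3 to compound 4 (0.90 log units; beyond the scatter), a 3.2-fold higher number from compound 1 to compound 4 (0.51 log units; beyond the scatter) and a 3.2-fold higher number from compound 2 to compound 4 (0.51 log units; beyond the scatter), although each step still rates as modest. The step from compound 1 shows that a five-membered aromatic ring with two hetero atoms does not by itself keep the number of compound 1, yet the ring and the link both differ in that step, so it cannot assign the rise to either one. No measurement at hand accounts for the size of these steps.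

Open, on these data alone, is whether the rise follows the 3,5-dimethyl-1H-pyrazol-1-yl ring or the longer link, a question that a 2-(2-chlorophenyl)ethyl group or a pyrazolylmethyl group on the same oxygen would help to separate. Also open, as far as these compounds go, is how this place responds to side groups of another kind, such as a 2-(dimethylamino)ethyl chain or a chain ending in a carboxylic acid.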